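Swapping a phenylpropyl arm for a piperidinyl amide

The source may hold more compounds than are shown below. What is called first, only, known or untested is meant among the compounds shown, and "the series" means these compounds.

Three compounds share one core and differ only in the group on the ring amine. Compound 1 `Cc1cccc2c1nc(COc1ccc(Cl)cc1)n2CCCC1CCN(C)CC1` carries a methyl there and gives 52 nM in an assay on AV12 cells for binding affinity to Neuropeptide Y receptor type 1 (Homo sapiens); on this read-out higher numbers stand for weaker inhibition and lower numbers for stronger inhibition. Compound 2 `Cc1cccc2c1nc(COc1ccc(Cl)cc1)n2CCCC1CCN(CCCc2ccccc2)CC1` gives 57 nM in this assay, a step of a 1.1-fold higher number from compound 1 to compound 2 (0.04 log units; within the scatter). Compound 3 `Cc1cccc2c1nc(COc1ccc(Cl)cc1)n2CCCC1CCN(CC(=O)N2CCCCC2)CC1` gives 136 nM, a step of a 2.6-fold higher number from compound 1 to compound 3 (0.42 log units; beyond the scatter) and of a 2.4-fold higher number from compound 2 to compound 3 (0.38 log units; beyond the scatter). Compound 2 thus sits in the middle of the three numbers, close to compound 1 and some way from compound 3.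

Compound 4 `Cc1cccc2c1nc(COc1ccc(Cl)cc1)n2CCCC1CCN(C(=O)CCN2CCCCC2)CC1` is the unmeasured case, and its change from compound 2 is (2-(piperidin-1-yl)ethyl)carbonyl in place of 3-phenylpropyl on an amine nitrogen in a ring. Like compound 3 it brings a carbonyl to the ring amine, and the steps that bear on it are those to compound 3, both modest. Compound 4 is therefore expected to show a modest weakening, estimated at a 1.9-fold higher number from compound 2 to compound 4 (0.29 log units; within the scatter). The estimate for compound 4 in this assay is 110 nM, within a range from 55 nM to 220 nM.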

Compound 4, inhibition constant: 260 nM
Beside the measured number, compound 4's estimate is 2.4-fold (0.37 log units) below it; measured number above the stated range.
By their numbers in this assay, from the lowest: compounds 1 and 2 (each within the scatter of the next); then compounds 3 and 4 (each within the scatter of the next).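

At the ring amine, the swap of 3-phenylpropyl for (2-(piperidin-1-yl)ethyl)carbonyl keeps a nearly equal heavy-atom count, yet in this assay it gives a 4.6-fold higher number from compound 2 to compound 4 (0.66 log units; beyond the scatter), so the number of heavy atoms in the arm does not settle the result, although compound 1 and compound 2 had looked alike despite their very different arms. The same loss appears against the small methyl group, with a 5.0-fold higher number from compound 1 to compound 4 (0.70 log units; beyond the scatter), while the other piperidine-bearing arm stays close, with a 1.9-fold higher number from compound 3 to compound 4 (0.28 log units; within the scatter), a step too small to place compound 3 and compound 4 in any order. No measurement shown here explains these differences.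

This swap changes two things at once: a carbonyl now sits on the ring amine, and a piperidine ring replaces the phenyl ring. A 3-phenylpropanoyl arm, which keeps the phenyl ring with the carbonyl, and a 3-(piperidin-1-yl)propyl arm, which keeps the piperidine ring without it, would be needed to separate the two changes.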